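Longer linker to the terminal group: working notes

The source may report more compounds than this note shows. Statements on the series, on what has been measured and on what is new or still open speak of the compounds shown alone.

All numbers here come from a functional assay on NCI-H1299 cells (Homo sapiens) for inhibition, read by CCK-8 assay, with a stated time of 72 h, tested at 1 uM; a lower number here means a weaker effect, a higher number a stronger effect of the compound at the concentration tested.

Compound 1, `CN(C)C(=O)c1cc2cnc(Nc3ccc(C(=O)NCCCN=C=S)cc3)nc2n1C1CCCC1`, gives 65.1%.
Compound 2, `CN(C)C(=O)c1cc2cnc(Nc3ccc(C(=O)NCCCCN=C=S)cc3)nc2n1C1CCCC1`, gives 55.2%.
Compound 3, `CN(C)C(=O)c1cc2cnc(Nc3ccc(C(=O)NCCCCN=C=S)cc3F)nc2n1C1CCCC1`, gives 28.7%.

Compound 1 and compound 2 differ in one place: a group of 4 heavy atoms (2 carbon, 1 nitrogen, 1 sulfur; no ring) in place of a group of 3 heavy atoms (1 carbon, 1 nitrogen, 1 sulfur; no ring), on a saturated chain carbon, three bonds along the chain from an amide-type nitrogen. The step is a number 9.9 percentage points lower from compound 1 to compound 2 (within the scatter). Compound 2 and compound 3 differ by fluoro in place of hydrogen on an aromatic carbon, and the step is a number 26.5 percentage points lower from compound 2 to compound 3 (beyond the scatter). Compound 3 stands lowest of the three, and both of the other two lie beyond the scatter above it. Between compound 1 and compound 3 the difference is not broken down here.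

Compound 4, `CN(C)C(=O)c1cc2cnc(Nc3ccc(C(=O)NCCCCCN=C=S)cc3F)nc2n1C1CCCC1`, is not yet measured. It differs from compound 3 in one place: a group of 4 heavy atoms (2 carbon, 1 nitrogen, 1 sulfur; no ring) in place of a group of 3 heavy atoms (1 carbon, 1 nitrogen, 1 sulfur; no ring), on a saturated chain carbon, four bonds along the chain from an amide-type nitrogen. This is the same kind of change as that from compound 1 to compound 2, not the same: there the group sat three bonds along the chain from an amide-type nitrogen, here it sits four bonds along the chain from an amide-type nitrogen, and the ring of compound 3 carries the fluoro that compound 1 lacks.

Among the compounds with values here, the expectation for compound 4 rests on the one earlier step of this kind, which was a number 9.9 percentage points lower from compound 1 to compound 2 (within the scatter) and lay within the scatter. A step of the same order is expected, a number 7.7 percentage points lower from compound 3 to compound 4 (within the scatter), with no reason from the measured compounds to expect more. Compound 4 is thus estimated at 21%, with a range from 6% to 38%.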

Compound 4, a percentage reported as inhibition, at one concentration (the size of the read-out at that concentration, not a potency): 36.1%
Beside the measured number, compound 4's estimate is 15.1 percentage points below it, and the stated range covers the measured number.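

In this assay, lengthening the chain on the fluoro-bearing core gives a number 7.4 percentage points higher from compound 3 to compound 4 (within the scatter), so this step alone shows no clear effect of the added chain carbon. Set beside the earlier step, the change does not carry from one core to the other as a step of fixed size and direction: the same change on two cores in this assay, a number 9.9 percentage points lower (within the scatter) from compound 1 to compound 2 and a number 7.4 percentage points higher (within the scatter) from compound 3 to compound 4, 17.3 percentage points apart, beyond the scatter of two such steps. This does not show that either core truly responds to lengthening, since each step on its own stays within the scatter, and two pairs cannot separate the role of the fluoro from that of the starting chain length, nor do readings at a single concentration give potency.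

The compounds shown leave open whether the fluoro step seen from compound 2 to compound 3 would recur on the chains of compound 1 or compound 4, and whether a chain longer than that of compound 4 would move the number beyond the scatter on either core. They also leave open how an amine or a carboxylic acid in place of the terminal group would read at the end of these chains.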